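The compounds below may be only part of what the source reports. "The series", "measured", "known", "first", "only" and "open" are said of these compounds alone.

Three compounds with closely related cores carry a saturated chain ending in a piperidin-1-yl ring. In an assay on membranes from brain for displacement of a labelled ligand from Sigma non-opioid intracellular receptor 1 (Cavia porcellus) (a higher number here means a weaker inhibitor, a lower number a stronger inhibitor), compound 1 `COc1ccc2c(CCCCN3CCC(C)(C)CC3)cccc2c1` gives 2.25 nM, the highest of the three numbers, yet compound 2 `COc1ccc2c(c1)CCCC2CCCN1CCC(C)CC1` with 1.78 nM and compound 3 `COc1ccc2c(CCCN3CCC(C)CC3)cccc2c1` with 1.5 nM both lie within the scatter of it, so no order among them can be read. Compound 4 `COc1ccc2c(CCCCN3CCC[C@H](C)C3)cccc2c1` has not yet been measured. It differs from compound 1 in one place: 3-methylpiperidin-1-yl in place of 4,4-dimethylpiperidin-1-yl on a saturated chain carbon, four bonds along the chain from an aromatic carbon. For the measured compounds named here, no measured pair isolates such a change, so the expected step from compound 1 to compound 4 in this assay is a 1.2-fold lower number from compound 1 to compound 4 (0.07 log units; within the scatter), nothing beyond the scatter in either direction. Compound 4 is therefore estimated at 1.9 nM, within 0.6 nM to 6 nM.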

Compound 4, inhibition constant: 0.66 nM
Beside the measured number, compound 4's estimate is 2.9-fold (0.46 log units) above it, and the stated range covers the measured number.
By their numbers in this assay, from the lowest: compound 4; then compounds 3, 2 and 1 (each within the scatter of the next).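

In this assay, for the compounds shown here, the ring at the end of the chain proves able to move the number: 3-methylpiperidin-1-yl in place of 4,4-dimethylpiperidin-1-yl brings a 3.4-fold lower number from compound 1 to compound 4 (0.53 log units; beyond the scatter) and is the first step here beyond the scatter. The change removes one methyl group and relocates the remaining one together, so the step belongs to the whole swap. Nothing measured here explains it.

As far as these compounds go, whether the count of methyl groups or their place matters more stays open. Neither an unsubstituted piperidin-1-yl ring on this chain nor the mirror-image form of the 3-methylpiperidin-1-yl group appears among these compounds.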